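The source may hold more compounds than are shown below. What is called first, only, known or untested is meant among the compounds shown, and "the series" means these compounds.

Three compounds share a frame in which two acyl groups flank a selenium-bearing carbon, and each was tested in a functional assay on PC-3 cells (Homo sapiens) for cytotoxicity, read by MTT assay, with a stated time of 72 h; a lower number here means a stronger inhibitor of growth, a higher number a weaker inhibitor of growth. Compound 1, `C[Se]/C(=N\C(=O)c1cc2ccccc2s1)NC(=O)c1cc2ccccc2s1`, gives 37200 nM in this assay. Compound 2, `O=C(/N=C(/NC(=O)c1cccs1)[Se]Cc1ccccc1)c1cccs1`, gives 49900 nM in this assay. Compound 3, `O=C(/N=C(/NC(=O)c1cc(-c2ccccc2)nc2ccccc12)[Se]Cc1ccccc1)c1cc(-c2ccccc2)nc2ccccc12`, gives 39300 nM in this assay. Compound 1 has the lowest of the three numbers, yet its distance to compound 3 and to compound 2 lies within the scatter, so no order among the three can be drawn, and none of them stands out as stronger or weaker.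

The next compound, compound 4, is `O=C(/N=C(/NC(=O)c1cc2ccccc2s1)[Se]Cc1ccccc1)c1cc2ccccc2s1`. It differs from compound 1 in one place: phenyl in place of hydrogen on a saturated chain carbon bound to a selenium atom. Compounds 2 and 3 both carry a benzyl on selenium, and their values sit close to that of compound 1, which carries only a methyl there. Among the compounds with values here, no direct step between measured compounds is available for this change, so the expectation rests on that resemblance alone. The expected step of a 1.1-fold higher number from compound 1 to compound 4 (0.05 log units; within the scatter) is small, with no clear direction beyond the scatter. Compound 4 is therefore estimated at 42000 nM in this assay, within a range from 15000 nM to 110000 nM.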

Compound 4, concentration for 50% growth inhibition: 30500 nM
Compound 4: the middle estimate sits 1.4-fold (0.14 log units) above what was measured, and the stated range covers the measured number.
By their numbers in this assay, from the lowest: compounds 4, 1, 3 and 2 (each within the scatter of the next).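

With the rest of the molecule held the same, the swap of methyl to benzyl can now be read directly rather than inferred from compounds that also differ in their acyl groups: in this assay, the phenyl placed on a saturated chain carbon bound to a selenium atom gives a 1.2-fold lower number from compound 1 to compound 4 (0.09 log units; within the scatter) as its step. So this position accepts a whole added aromatic ring, six heavy atoms of carbon, without any change in growth inhibition that can be told apart from the usual spread of repeated measurements. Nothing shown here offers a measured property that bears on this result.

As far as these compounds go, what remains open is whether any group on selenium can move the number clearly, for instance a longer chain such as butyl, or a chain ending in an amine or a carboxylic acid. Also open is whether the same swap of methyl to benzyl would read the same way with the acyl groups of compound 2 or compound 3, since the compounds shown pair it with only one acyl group.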